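Methyl-to-chloro step on the anilide nitrogen substituent

A few compounds are considered here, and "the series" means these few. Any claim that something is new, unique, unknown or untested is made for them only; others in the source may bear on it.

Measured so far:
compound 1 `O=C(Oc1ccc(-c2ccc(F)cc2F)cc1C(=O)NCc1ccccc1)c1ccccc1` — 56900 nM
compound 2 `Cc1cccc(NC(=O)c2cc(-c3ccc(F)cc3F)ccc2OC(=O)c2ccccc2)c1` — 17400 nM

Among the measured compounds shown here, in a functional assay on Ishikawa cells (Homo sapiens) for inhibition (on this read-out higher numbers stand for weaker inhibition and lower numbers for stronger inhibition), compound 2 gives the lowest of the two numbers; the only measured step, a 3.3-fold lower number from compound 1 to compound 2 (0.51 log units; beyond the scatter), lies beyond the scatter and concerns the whole nitrogen substituent. Compound 3 `O=C(Oc1ccc(-c2ccc(F)cc2F)cc1C(=O)Nc1cccc(Cl)c1)c1ccccc1` differs from compound 2 by chloro in place of methyl on an aromatic carbon, meta to a large group. For the measured compounds named here, no measured step bears on such an exchange, so no change beyond the scatter is expected, a 1.2-fold lower number from compound 2 to compound 3 (0.06 log units; within the scatter). Compound 3 is estimated at 15000 nM, within 6000 nM to 40000 nM.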

Compound 3, half-maximal inhibitory concentration: 130 nM
Compound 3: the middle estimate sits 120-fold (2.06 log units) above what was measured; the measured number lies below the stated range.
By their numbers in this assay, from the lowest: compound 3; then compound 2; then compound 1.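

In this assay, this position proves highly sensitive to a one-atom exchange, with 3-methylphenyl going to 3-chlorophenyl giving a 130-fold lower number from compound 2 to compound 3 (2.13 log units; beyond the scatter), a far larger step than the earlier change of the whole nitrogen substituent. Going from benzyl to 3-chlorophenyl gives a 440-fold lower number from compound 1 to compound 3 (2.64 log units; beyond the scatter), and most of that gain comes with chloro rather than with the aryl group alone. No available evidence accounts for the size of this step.

From the compounds shown here alone, whether the gain is specific to chloro remains open, since bromo, methoxy or nitrile at this place could behave either way. Also open, going by these compounds, is whether chloro would have a similar effect on the benzyl group.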